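The compounds below may be only part of what the source reports. "The series", "measured", "known", "first", "only" and "open" are said of these compounds alone.

Measured in a toxicity assay on microsomes from liver (Homo sapiens) for metabolic stability, read by LC-MS, using NADPH, tested at 1 uM; on this read-out higher numbers stand for fast clearance and lower numbers for slow clearance:
Compound 1 `CCOc1ncc(-c2nc(C(F)(F)F)sc2N2CCN(C(=O)Cn3nc(C)nc3C)[C@H](C)C2)cn1`: < 10 mL.min-1.g-1, a limit of the assay
Compound 2 `Cc1nc(C)n(CC(=O)N2CCN(c3sc(C(F)(F)F)nc3-c3cnc(OC(C)C)nc3)C[C@H]2C)n1`: 16 mL.min-1.g-1
Compound 3 `CCCc1ncc(-c2nc(C(F)(F)F)sc2N2CCN(C(=O)Cn3nc(C)nc3C)[C@H](C)C2)cn1`: 80 mL.min-1.g-1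

Compound 3 stands highest of these, and the nearest number belongs to compound 2 at 16 mL.min-1.g-1. Compound 4 `Cc1nc(C)n(CC(=O)N2CCN(c3sc(C(F)(F)F)nc3-c3cnc(C4CC4)nc3)C[C@H]2C)n1` differs from compound 3 in one place: cyclopropyl in place of propyl on an aromatic carbon. Among the measured compounds shown here, two measured steps bear on this place, both ending in propyl: a 5.0-fold higher number from compound 2 to compound 3 (0.70 log units; beyond the scatter) and an at least 8.0-fold higher number from compound 1 to compound 3 (0.90 log units; beyond the scatter). Neither involves cyclopropyl, so the size of the change remains uncertain. Since compound 3 holds the highest number at 80 mL.min-1.g-1, a modest fall in this assay is expected. The expected step is a 2.3-fold lower number from compound 3 to compound 4 (0.36 log units; beyond the scatter). For compound 4 the estimated value is 35 mL.min-1.g-1, with an expected range of 14 mL.min-1.g-1 to 80 mL.min-1.g-1.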

Compound 4, intrinsic clearance in microsomes: < 10 mL.min-1.g-1
Compound 4: only a limit was reported (the forecaster's own chance of this, stated with the estimate: 10%); middle value at least 3.5-fold (0.54 log units) away from the limit.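

Replacing propyl with cyclopropyl, each of three carbons, on the aromatic carbon between two ring nitrogen atoms gives an at least 8.0-fold lower number from compound 3 to compound 4 (0.90 log units; beyond the scatter), so an all-carbon group here need not carry the high number of compound 3. Replacing isopropoxy with cyclopropyl gives an at least 1.6-fold lower number from compound 2 to compound 4 (0.20 log units; that floor lies within the scatter), and the step from ethoxy to cyclopropyl cannot be read. For compound 4 only a limit of the assay stands, and this sets the size of both readable steps as floors: the limit of < 10 mL.min-1.g-1 in this assay, at which 2 of the 4 values shown sit.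

The compounds shown leave open how a cyclobutyl ring, an amine or a longer chain at this position would read in this assay.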